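The source may report more compounds than this note shows. Statements on the series, on what has been measured and on what is new or still open speak of the compounds shown alone.

Series notes. For the measured compounds named here, compound 1 `N#Cc1cnc(NCc2cnccc2C(F)(F)F)cc1NC[C@H]1CC[C@H](O)CC1` carries a (4-hydroxycyclohexyl)methyl group on a nitrogen on an aromatic ring; in an assay on isolated protein for inhibition of protein kinase C theta type (Homo sapiens), read by TR-FRET, with a stated time of 2 h (a higher number here means a weaker inhibitor, a lower number a stronger inhibitor), compound 1 gives 50 nM, the lowest of the two numbers so far. Compound 2 `N#Cc1cnc(NCc2cnccc2C(F)(F)F)cc1N[C@H]1CC[C@@H](n2cncn2)CC1` in this assay gives 100 nM; the two values sit within the scatter of each other. Compound 3 `CC1(C)[C@H](Nc2cc(NCc3cnccc3C(F)(F)F)ncc2C#N)C[C@H]1C(N)=O` is not yet measured. Relative to compound 1 the change is 3-carbamoyl-2,2-dimethylcyclobutyl in place of (4-hydroxycyclohexyl)methyl on a nitrogen on an aromatic ring. Going by the values given here, with no measured step to lean on, only a small weakening is expected, a 2.4-fold higher number from compound 1 to compound 3 (0.38 log units; beyond the scatter), not clearly beyond the scatter. For compound 3 in this assay the estimate is 120 nM, with a range of 40 nM to 400 nM.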

Compound 3, half-maximal inhibitory concentration: 140 nM
The estimate for compound 3 lay 1.2-fold (0.07 log units) below the measured number, and the stated range covers the measured number.
By their numbers in this assay, from the lowest: compounds 1, 2 and 3 (each within the scatter of the next, the first and the last beyond it).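

With 3-carbamoyl-2,2-dimethylcyclobutyl in place of (4-hydroxycyclohexyl)methyl on a nitrogen on an aromatic ring, this assay shows a 2.8-fold higher number from compound 1 to compound 3 (0.45 log units; beyond the scatter) and the step is modest. This position therefore accepts a four-membered ring bearing a carbamoyl group at a modest cost in this assay. Ring size, the methyl groups and the carbamoyl group all change in this one step, and no measurement on the compounds explains the result.

As far as these compounds go, it remains open how much each of these parts contributes. A carboxylic acid or an amine in place of the carbamoyl group on the same cyclobutyl ring is also untested among the compounds shown.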